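The source may hold more compounds than are shown below. What is called first, only, known or untested is meant among the compounds shown, and "the series" means these compounds.

Compound 1 `COc1ccc2c(=O)c(/C=C/C(=O)Nc3ccc(Cl)cc3)coc2c1` is the starting point. In a functional assay (QGY7701 cells, Homo sapiens) for inhibition, read by MTT assay, with a stated time of 48 h (on this read-out lower numbers stand for stronger inhibition and higher numbers for weaker inhibition), compound 1 gives > 100000 nM, which is a limit of the measurement rather than a number. Compound 2 `COc1ccc(NC(=O)/C=C/c2coc3cc(O)ccc3c2=O)cc1` in this assay gives > 100000 nM, again a limit. Both therefore stand at the limit of > 100000 nM in this assay, at which 2 of the 3 values shown sit. Compound 3 `COc1ccc2c(=O)c(/C=C/C(=O)Nc3ccccc3Cl)coc2c1` is the only one of the three with a number, giving 23000 nM in this assay. That change is an at least 4.3-fold lower number from compound 1 to compound 3 (0.63 log units; beyond the scatter), brought by 2-chlorophenyl in place of 4-chlorophenyl on an amide-type nitrogen. Compound 4 `COc1ccc2c(=O)c(/C=C/C(=O)NCc3ccc(F)cc3F)coc2c1` has not yet been measured in this assay. It differs from compound 1 by 2,4-difluorobenzyl in place of 4-chlorophenyl on an amide-type nitrogen. No measured step alters the group on the amide-type nitrogen in this way, so the one step shown bears only loosely on it. Because compound 1 sits at the limit of > 100000 nM in this assay, at which 2 of the 3 values shown sit, its own value is open-ended, and a further limit for compound 4 cannot be ruled out. The expected step is an at least 1.6-fold lower number from compound 1 to compound 4 (0.22 log units; that floor lies within the scatter). Compound 4 is estimated at 60000 nM, with a range from 15000 nM to 200000 nM.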

Compound 4, half-maximal inhibitory concentration: > 100000 nM
Compound 4 was reported as a limit; the forecaster's own chance of this, stated with the estimate: 45%; at least 1.6-fold (0.22 log units) between middle value and limit.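

On the amide-type nitrogen, the 2,4-difluorobenzyl group of compound 4 does not keep the measurable inhibition seen with the 2-chlorophenyl group of compound 3 in this assay, the change being an at least 4.3-fold higher number from compound 3 to compound 4 (0.63 log units; beyond the scatter). Compound 1 and compound 4 both stand as limits, not numbers, and the step between them cannot be read. Only one compound shown gives a number, and the others now stand together at one limit: the limit of > 100000 nM in this assay, at which 3 of the 4 values shown sit.

The compounds shown leave open whether a plain phenyl or an unsubstituted benzyl group on the same nitrogen would give a number, which would help separate the part played by the ring substituents from that of the benzyl chain. They also leave open how an amine or a carboxylic acid on that ring would read in this assay.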